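The compounds below may be only part of what the source reports. "The series", "measured", "known", "first", "only" and "open" are said of these compounds alone.

Measured in a functional assay on MT4 cells (Homo sapiens) for cytotoxicity; a higher number here means that more compound is tolerated, a lower number that less compound is tolerated:
Compound 1 `Cc1cn([C@@H]2O[C@H](CO[Si](C)(C)C(C)(C)C)[C@@]3(OS(=O)(=O)C(Br)=C3N)[C@H]2O[Si](C)(C)C(C)(C)C)c(=O)[nH]c1=O`: 18000 nM
Compound 2 `Cc1cn([C@@H]2O[C@H](CO[Si](C)(C)C(C)(C)C)[C@@]3(OS(=O)(=O)C(I)=C3N)[C@H]2O[Si](C)(C)C(C)(C)C)c(=O)n(C)c1=O`: 3900 nM
Compound 3 `Cc1cn([C@@H]2O[C@H](CO[Si](C)(C)C(C)(C)C)[C@@]3(OS(=O)(=O)C(I)=C3N)[C@H]2O[Si](C)(C)C(C)(C)C)c(=O)[nH]c1=O`: 4300 nM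

On these numbers, compound 3 sits level with compound 2 and clearly under compound 1. Its neighbour for this step is compound 4 `Cc1cn([C@@H]2O[C@H](CO[Si](C)(C)C(C)(C)C)[C@@]3(OS(=O)(=O)C(Cl)=C3N)[C@H]2O[Si](C)(C)C(C)(C)C)c(=O)[nH]c1=O`, where chloro replaces iodo on a double-bonded ring carbon (chloro in place of iodo on a double-bonded ring carbon).

Two measured steps can be weighed. The more relevant one also swaps a halogen at this same carbon, iodo in place of bromo: a 4.2-fold lower number from compound 1 to compound 3 (0.62 log units; beyond the scatter). That step is modest but beyond the scatter. The other, hydrogen in place of methyl on an aromatic nitrogen, changes a different part of the molecule and stays within the scatter: a 1.1-fold higher number from compound 2 to compound 3 (0.04 log units; within the scatter). For the measured compounds named here, no chloro compound has been measured yet, leaving the halogen swap as the only guide. Leaving iodo for another halogen may therefore reverse that step, so a modest rise is expected in this assay.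

The expected change is a 4.0-fold higher number from compound 3 to compound 4 (0.60 log units; beyond the scatter).

For compound 4 the estimated value is 17000 nM, with an expected range of 6000 nM to 50000 nM.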

Compound 4, half-maximal cytotoxic concentration: 5400 nM
Compound 4: middle estimate off by 3.1-fold (0.50 log units), on the high side; measured number outside the range, below it.
By their numbers in this assay, from the lowest: compounds 2, 3 and 4 (each within the scatter of the next); then compound 1.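

In this assay, chloro in place of iodo on this double-bonded ring carbon gives a 1.3-fold higher number from compound 3 to compound 4 (0.10 log units; within the scatter), so these two halogens cannot be told apart here. Chloro in place of bromo gives a 3.3-fold lower number from compound 1 to compound 4 (0.52 log units; beyond the scatter), which leaves compound 1 as the one that stands apart, and the number does not move steadily from chloro through bromo to iodo across compound 4, compound 1 and compound 3. Nothing available here bears on why the bromo compound differs.

Still open, on these data alone, is whether fluoro at this carbon would sit with chloro and iodo or with bromo. The compounds shown also leave open how a group other than a halogen, such as a hydrogen, a methyl or a nitrile, would behave there.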